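Thioether substitution on the shared core of compound 1

The compounds below may be only part of what the source reports. "The series", "measured", "known", "first", "only" and "open" are said of these compounds alone.

Measured so far in a functional assay on MCF7 cells (Homo sapiens) for inhibition, read by MTT assay, with a stated time of 72 h; on this read-out higher numbers stand for weaker inhibition and lower numbers for stronger inhibition:
- compound 1, `Cc1cc(Nc2cc(-c3ccccc3)[nH]n2)n2ncnc2n1`: > 50000 nM
- compound 2, `Cc1cc(Nc2cc(-c3ccc(Cl)cc3)[nH]n2)n2nc(SCc3ccc(Br)cc3)nc2n1`: 3620 nM
- compound 3, `Cc1ccc(Cn2ccc(Nc3cc(C)nc4nc(SCc5ccc(Br)cc5)nn34)n2)cc1`: 11300 nM

Compound 1 carries no substituent on the aromatic carbon between two ring nitrogen atoms of its fused five-membered ring. In this assay compound 1 reaches only the limit of the measurement, > 50000 nM, so no number is known for it; this is the case described by the limit of > 50000 nM in this assay, at which 1 of the 3 values shown sits. Compound 2 and compound 3 each carry a sulfur-linked group on the shared core and both give numbers within the measured range, with compound 2 at 3620 nM and compound 3 at 11300 nM. Going by the values given here, no single-change step between measured compounds is available in this set.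

Compound 4, `Cc1cc(Nc2cc(-c3ccccc3)[nH]n2)n2nc(SCC3CC3)nc2n1`, is not yet measured. It differs from compound 1 by (cyclopropylmethyl)sulfanyl in place of hydrogen on an aromatic carbon. Given that compound 1 sits at a limit and the two substituted analogues give measurable numbers, the step from compound 1 to compound 4 is expected to be a gain in inhibition beyond the usual scatter, estimated as an at least 3.3-fold lower number from compound 1 to compound 4 (0.52 log units; beyond the scatter). Compound 4 is expected to give about 15000 nM, within roughly 4000 nM to 50000 nM.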

Compound 4, half-maximal inhibitory concentration: > 50000 nM
Compound 4 was reported as a limit (the forecaster's own chance of this, stated with the estimate: 30%); at least 3.3-fold (0.52 log units) between middle value and limit.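

No step can be read between compound 1 and compound 4 in this assay, as each is reported only as a limit: the limit of > 50000 nM in this assay, at which 2 of the 4 values shown sit.

The compounds shown leave open whether (cyclopropylmethyl)sulfanyl in place of hydrogen changes inhibition on the shared core at all, and no single-change step connects compound 2 or compound 3 to either compound.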